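Thiazole to Thiadiazole on a Weakly Antiproliferative Pyridine Amide

The source may report more compounds than this note shows. Statements on the series, on what has been measured and on what is new or still open speak of the compounds shown alone.

Two compounds have been run in a functional assay on HCC78 cells (Homo sapiens) for antiproliferative activity, read by MTT assay, with a stated time of 48 h; on this read-out higher numbers stand for weaker inhibition and lower numbers for stronger inhibition. Compound 1 `CC(Oc1cccnc1Nc1cnn(C)c1)c1cccc(C(=O)NCc2ccc(Cl)c(C(F)(F)F)c2)c1` gives 48600 nM in this assay. Compound 2 `Cc1ccc(CNC(=O)c2cccc(C(C)Oc3cccnc3Nc3nccs3)c2)cc1` gives 27100 nM in this assay, and the two numbers sit within the usual scatter of each other, so neither is distinguished from the other. Compound 3 `Cc1ccc(CNC(=O)c2cccc(C(C)Oc3cccnc3Nc3nncs3)c2)cc1` differs from compound 2 by 1,3,4-thiadiazol-2-yl in place of 1,3-thiazol-2-yl on a nitrogen on an aromatic ring. Among the compounds with values here, no comparable step has been measured, so the expected step from compound 2 to compound 3 is a 1.1-fold higher number from compound 2 to compound 3 (0.04 log units; within the scatter), that is, nothing beyond the scatter in either direction. Compound 3 is therefore estimated at 30000 nM, with a range from 10000 nM to 90000 nM.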

Compound 3, half-maximal inhibitory concentration: 17600 nM
For compound 3 the middle estimate is 1.7-fold (0.23 log units) above the measured one; the measured number falls inside the stated range.
By their numbers in this assay, from the lowest: compounds 3, 2 and 1 (each within the scatter of the next, the first and the last beyond it).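

Within the data shown here, this is the first comparison at this position, as compound 2 and compound 3 differ in one place only. In this assay, 1,3,4-thiadiazol-2-yl in place of 1,3-thiazol-2-yl on a nitrogen on an aromatic ring gives a 1.5-fold lower number from compound 2 to compound 3 (0.19 log units; within the scatter), so this one exchange leaves the two compounds undistinguished. Nothing available accounts for this result. Still open, going by these compounds, is whether a ring without sulfur, such as oxazol-2-yl, or a phenyl or a pyridin-2-yl group on that nitrogen would give a step beyond the scatter. Among these compounds, a single pair also cannot show whether the same exchange behaves alike on another amide side chain, such as the one in compound 1.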